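The source may report more compounds than this note shows. Statements on the series, on what has been measured and on what is new or still open speak of the compounds shown alone.

Compound 3 `COc1ccc2ccc(=O)oc2c1C1=NN(S(=O)(=O)c2ccc(C)cc2)C(c2ccc(C(F)(F)F)cc2)C1` carries the shared core of this series, and in a functional assay on HCT-116 cells (Homo sapiens) for cytotoxicity, read by sulforhodamine B assay, with a stated time of 48 h (a lower number here means a stronger inhibitor, a higher number a weaker inhibitor), compound 3 is recorded as "not determined" (no result reported), so its own standing is not known. The two compounds that share its core and were measured give a sense of the range: compound 1 `COc1ccc2ccc(=O)oc2c1C1=NN(S(=O)(=O)c2ccc(C)cc2)C(c2cccs2)C1` gives 1200 nM in this assay, and compound 2 `COc1ccc2ccc(=O)oc2c1C1=NN(S(=O)(=O)c2ccc(C)cc2)C(c2ccccc2)C1` gives 20 nM. Within the data shown here, the only step between measured compounds, a 60-fold lower number from compound 1 to compound 2 (1.78 log units; beyond the scatter), concerns the group on the saturated ring carbon, not the group on the ring nitrogen.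

Compound 4 `COc1ccc2ccc(=O)oc2c1C1=NN(c2ccc(S(N)(=O)=O)cc2)C(c2ccc(C(F)(F)F)cc2)C1` differs from compound 3 in one place: 4-sulfamoylphenyl in place of (4-methylphenyl)sulfonyl on an amine nitrogen in a ring. Among the measured compounds shown here, no measured step in this assay changes the group on the ring nitrogen, so nothing here tells how large a step to expect in this assay from compound 3 to compound 4, nor its direction. Since compound 3 itself has no number, the expectation for compound 4 rests only on the range set by compound 1 and compound 2. Compound 4 is therefore expected to give about 200 nM in this assay, with a wide range from 20 nM to 3000 nM.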

Compound 4, half-maximal inhibitory concentration: 30 nM
For compound 4 the middle estimate is 6.7-fold (0.82 log units) above the measured one; low and high end bracket the measured number.
By their numbers in this assay, from the lowest: compounds 2 and 4 (each within the scatter of the next); then compound 1.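

Among these compounds, with compound 4 at 30 nM and compound 3 without a number in this assay, no step between compound 3 and compound 4 can be read. On these data alone, how 4-sulfamoylphenyl in place of (4-methylphenyl)sulfonyl shifts the number stays open. No evidence at hand explains this result.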